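Thiazolidinone analogues: a naphthyl swap on two cores

A few compounds are considered here, and "the series" means these few. Any claim that something is new, unique, unknown or untested is made for them only; others in the source may bear on it.

Measured compounds:
Compound 1, `COc1ccc(/C=C2\S/C(=N\c3csc(-c4ccc(Cl)cc4)c3)NC2=O)cc1`: 1300 nM
Compound 2, `O=C1N/C(=N/c2csc(-c3ccc(Cl)cc3)c2)S/C1=C\c1ccc2ccccc2c1`: 3000 nM
Compound 3, `COc1ccc(/C=C2\S/C(=N\c3nc(-c4ccc(Cl)cc4)cs3)NC2=O)cc1`: 400 nM

The three measured compounds were tested in a functional assay on HCT-116 cells (Homo sapiens) for cytotoxicity, read by MTT assay, with a stated time of 72 h; on this read-out lower numbers stand for stronger inhibition and higher numbers for weaker inhibition. Compound 1 and compound 2 share one core and differ in one place: naphthalen-2-yl in place of 4-methoxyphenyl on a double-bonded chain carbon bound to a double-bonded ring carbon. This change gave a 2.3-fold higher number from compound 1 to compound 2 (0.36 log units; beyond the scatter). Compound 3 carries a different core; the difference between the two cores is not broken down here. Among the three, compound 3 gives the lowest number, and its steps to compound 1 and to compound 2 are both beyond the usual scatter of this assay.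

Compound 4, `O=C1N/C(=N/c2nc(-c3ccc(Cl)cc3)cs2)S/C1=C\c1ccc2ccccc2c1`, is the untested partner of compound 3. It differs from compound 3 in one place: naphthalen-2-yl in place of 4-methoxyphenyl on a double-bonded chain carbon bound to a double-bonded ring carbon. This is the same change, at the same place, that turned compound 1 into compound 2, so its earlier effect is the natural guide. Among the measured compounds shown here, on that basis compound 4 is expected to give a step of about a 2.3-fold higher number from compound 3 to compound 4 (0.35 log units; beyond the scatter) in this assay, a step close in size to the one seen from compound 1 to compound 2, because that earlier step was a 2.3-fold higher number from compound 1 to compound 2 (0.36 log units; beyond the scatter). For the measured compounds named here, with only one prior instance of the change, the expectation is held loosely. For compound 4 the estimate in this assay is 900 nM, with a likely range from 400 nM to 2000 nM.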

Compound 4, half-maximal inhibitory concentration: 1200 nM
Estimate against measurement, compound 4: 1.3-fold (0.12 log units) below, and the stated range covers the measured number.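

In this assay, naphthalen-2-yl in place of 4-methoxyphenyl on the second core gave a 3.0-fold higher number from compound 3 to compound 4 (0.48 log units; beyond the scatter), so the number rose on this core as it had on the first. Set side by side, the two steps point the same way and do not differ in size beyond what repeated measurement allows, so in this series the change carried from one core to the other with its direction and size kept: the same change on two cores in this assay, a 2.3-fold higher number (0.36 log units; beyond the scatter) from compound 1 to compound 2 and a 3.0-fold higher number (0.48 log units; beyond the scatter) from compound 3 to compound 4, 1.3-fold (0.11 log units) apart, within the scatter of two such steps. Among the compounds shown here, this rests on only two matched pairs in a single cell assay, so it sets no rule for other cores or other read-outs, and it does not show why naphthalen-2-yl gives the higher number on both cores.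

The compounds shown cover only two groups at this place, so it remains open whether an aryl group carrying an amine or a carboxylic acid, or a longer chain in place of the aryl group, would also shift the number by a similar amount on both cores. It also remains open which part of the structural difference between the two cores accounts for the lower numbers of the second core's compounds.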